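Phenyl to Benzyl Hydroxamate Swap on a Second Core

The source may report more compounds than this note shows. Statements on the series, on what has been measured and on what is new or still open speak of the compounds shown alone.

Measured so far in an assay on isolated protein for inhibition of protein deacetylase HDAC6 (Homo sapiens), read by fluorescence, with stated times of 5 min and 60 min; on this read-out higher numbers stand for weaker inhibition and lower numbers for stronger inhibition:
Compound 1 `O=C(CCC1C(=O)N(c2ccc(Cl)cc2)C(=O)N1Cc1ccccc1)Nc1ccc(C(=O)NO)cc1` gives 7.6 nM.
Compound 2 `O=C(CCC1C(=O)N(c2ccc(Cl)cc2)C(=O)N1Cc1ccccc1)NCc1ccc(C(=O)NO)cc1` gives 12.7 nM.
Compound 3 `Cc1ccc(CN2C(=O)N(C3CCCCC3)C(=O)C2CCC(=O)Nc2ccc(C(=O)NO)cc2)cc1` gives 10.3 nM.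

Compound 4 `Cc1ccc(CN2C(=O)N(C3CCCCC3)C(=O)C2CCC(=O)NCc2ccc(C(=O)NO)cc2)cc1` has not yet been measured in this assay. It differs from compound 3 by 4-(hydroxycarbamoyl)benzyl in place of 4-(hydroxycarbamoyl)phenyl on an amide-type nitrogen, which is the same change as that from compound 1 to compound 2, (4-(hydroxycarbamoyl)benzyl in place of 4-(hydroxycarbamoyl)phenyl on an amide-type nitrogen). That earlier step gave a 1.7-fold higher number from compound 1 to compound 2 (0.22 log units; within the scatter). The difference between the two cores, that of compound 1 and that of compound 3, is not broken down here. Compound 3 and compound 2 sit close together, and compound 1 is not far off either.

Among the measured compounds shown here, with only one earlier instance of the change, the step from compound 3 to compound 4 is expected to be similar in size and direction, a 1.7-fold higher number from compound 3 to compound 4 (0.22 log units; within the scatter), resting on a 1.7-fold higher number from compound 1 to compound 2 (0.22 log units; within the scatter). Compound 4 is therefore estimated at 17 nM in this assay, with a likely range from 8 nM to 36 nM.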

Compound 4, half-maximal inhibitory concentration: 17 nM
For compound 4 middle estimate and measured number coincide at the digits printed; the range from low to high includes it.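

In this assay, placing 4-(hydroxycarbamoyl)benzyl where 4-(hydroxycarbamoyl)phenyl stood gave a 1.7-fold higher number from compound 3 to compound 4 (0.22 log units; within the scatter). Set beside the earlier case, the change carried over from one core to the other with no visible difference in size: the same change on two cores in this assay, a 1.7-fold higher number (0.22 log units; within the scatter) from compound 1 to compound 2 and a 1.7-fold higher number (0.22 log units; within the scatter) from compound 3 to compound 4, 1.0-fold (0.01 log units) apart, within the scatter of two such steps This rests on only two cores and on steps that each lie within the scatter, so it shows that the change made no clear difference on either core, not that it truly weakens inhibition or that it would behave alike on other cores.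

The compounds shown leave open how a longer chain, such as 4-(hydroxycarbamoyl)phenethyl, would read on that amide-type nitrogen. Also open, on these data alone, is whether the same change would hold on a core carrying an amine or a carboxylic acid.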